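The source may hold more compounds than are shown below. What is called first, only, known or untested is meant among the compounds shown, and "the series" means these compounds.

Measured compounds:
compound 1 `CC(=O)OCC(CCn1cc(C#Cc2ccc(Br)cc2)c(=O)n(C(=O)c2ccccc2)c1=O)COC(C)=O`: 47200 nM
compound 2 `CC(=O)OCC(CCn1cc(C#CCCCCl)c(=O)n(C(=O)c2ccccc2)c1=O)COC(C)=O`: 52800 nM
compound 3 `O=c1[nH]c(=O)n(CCC(CO)CO)cc1C#Cc1cc(F)cc(F)c1`: 31200 nM

All three numbers come from a functional assay on HeLa cells (Homo sapiens) for antiproliferative activity, read by MTT assay, with a stated time of 72 h; a lower number here means a stronger inhibitor, a higher number a weaker inhibitor. Compound 3 stands within the scatter of both of the others: its gap to compound 1 and its gap to compound 2 are each within the scatter, so no order among the three can be read from these values. Compound 4 `CC(C)(C)C#Cc1cn(CCC(CO)CO)c(=O)[nH]c1=O` is not yet measured; it differs from compound 3 by tert-butyl in place of 3,5-difluorophenyl on a triple-bonded carbon. For the measured compounds named here, the one measured step at the same place, a 1.1-fold higher number from compound 1 to compound 2 (0.05 log units; within the scatter), exchanged an aromatic ring for a chain on the triple-bonded carbon and left the number within the scatter. On that basis compound 4 is expected to show no step beyond the scatter, estimated as a 1.1-fold higher number from compound 3 to compound 4 (0.05 log units; within the scatter). The value of compound 4 in this assay is therefore estimated at 35000 nM, with a range from 12000 nM to 100000 nM.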

Compound 4, half-maximal inhibitory concentration: > 100000 nM
Compound 4: a limit, no number (the forecaster's own chance of this, stated with the estimate: 20%); middle value at least 2.8-fold (0.45 log units) from the limit.
By their numbers in this assay, from the lowest: compounds 3, 1 and 2 (each within the scatter of the next). At a limit, above all of these: compound 4.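

In this assay, tert-butyl in place of 3,5-difluorophenyl on a triple-bonded carbon brings an at least 3.2-fold higher number from compound 3 to compound 4 (0.50 log units; beyond the scatter), so this place is not indifferent to what it carries. Compound 4 stands only as a limit, not a number: the limit of > 100000 nM in this assay, at which 1 of the 4 values shown sits. An aromatic ring cannot be exchanged freely for any group without a ring here, although 3-chloropropyl in compound 2 went against this on a differently substituted core.

From the compounds shown here alone, whether the ring's absence or the tert-butyl itself matters stays open. An unsubstituted phenyl, an amine or a longer chain at this place on the core of compound 3 could separate the two.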